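Cinnamate ester series: removing the catechol hydroxyls

The compounds below may be only part of what the source reports. "The series", "measured", "known", "first", "only" and "open" are said of these compounds alone.

Compound 2 `CS(=O)(=O)c1ccc(-c2nc(SCCCOC(=O)/C=C/c3ccc(O)c(O)c3)nn2-c2ccc(Br)cc2)cc1` stands in the middle of three measured analogues. In a functional assay on A549 cells (Homo sapiens) for antiproliferative activity, read by MTT assay, with a stated time of 72 h (on this read-out higher numbers stand for weaker inhibition and lower numbers for stronger inhibition), compound 2 gives 11200 nM. Compound 1 `CC(=O)Oc1ccc(/C=C/C(=O)OCCCSc2nc(-c3ccc(S(C)(=O)=O)cc3)n(-c3ccc(Br)cc3)n2)cc1OC(C)=O` gives 12900 nM, and compound 3 `CS(=O)(=O)c1ccc(-c2nc(SCCCOC(=O)/C=C/c3ccc(O)c(O)c3)nn2-c2ccc(F)cc2)cc1` gives 9520 nM; both lie within the scatter of compound 2, so the three cannot be ordered against one another. For the measured compounds named here, the only single-point step, a 1.2-fold lower number from compound 2 to compound 3 (0.07 log units; within the scatter), concerns fluoro in place of bromo on an aromatic carbon and is itself within the scatter.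

Compound 4 `CS(=O)(=O)c1ccc(-c2nc(SCCCOC(=O)/C=C/c3ccccc3)nn2-c2ccc(Br)cc2)cc1` is not yet measured. It differs from compound 2 by phenyl in place of 3,4-dihydroxyphenyl on a double-bonded chain carbon bound to a double-bonded chain carbon. Going by the values given here, no measured step touches this part of the molecule; the one step available concerns a different position and was flat. On this basis the step of a 1.3-fold higher number from compound 2 to compound 4 (0.10 log units; within the scatter) is expected to be small, at most a modest move toward a higher number, and may not exceed the scatter. Compound 4 is therefore estimated at 14000 nM, with a range from 5000 nM to 40000 nM.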

Compound 4, half-maximal inhibitory concentration: 22300 nM
Beside the measured number, compound 4's estimate is 1.6-fold (0.20 log units) below it; the range from low to high includes it.
By their numbers in this assay, from the lowest: compounds 3, 2, 1 and 4 (each within the scatter of the next, the first and the last beyond it).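

In this assay, for the compounds shown here, the one step at this position, phenyl in place of 3,4-dihydroxyphenyl, is a 2.0-fold higher number from compound 2 to compound 4 (0.30 log units; within the scatter). The earlier compounds gave no reading of this change, and this step shows that removing both hydroxyls does not move the number beyond the scatter, so the 3,4-dihydroxyphenyl group is not shown to be needed for this level of activity. Nothing available bears on what lies behind this result.

The compounds shown leave open whether a single hydroxyl or a methoxy group on the phenyl ring would read differently from either end of this step, and whether an amine or a carboxylic acid there would move the number beyond the scatter. They also leave open whether the same removal of the hydroxyls would read alike with fluoro in place of bromo, as in compound 3.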